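The source may hold more compounds than are shown below. What is called first, only, known or untested is meant among the compounds shown, and "the series" means these compounds.

Of the compounds shown here, two sharing one core have been tested in a functional assay on HT-29 cells (Homo sapiens) for cytotoxicity, read by MTT assay, with a stated time of 24 h, tested at 6.4 ug/mL; a lower number here means a weaker effect, a higher number a stronger effect of the compound at the concentration tested. Compound 1 `Cn1c(-c2ccc(NC(=O)CSc3nc4cc(Cl)ccc4o3)cc2)nc(-c2ccccc2)c1-c1ccccc1` gives 29.4% in this assay, and compound 2 `Cn1c(-c2ccc(NC(=O)CSc3nc4ccccc4s3)cc2)nc(-c2ccccc2)c1-c1ccccc1` gives 36.8%. Going by the values given here, compound 2 has the highest of the two numbers, with compound 1 nearest; the single step of a number 7.4 percentage points higher from compound 1 to compound 2 (within the scatter) lies within the scatter, so the two values cannot be told apart.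

Compound 3 `Cn1nnnc1SCC(=O)Nc1ccc(-c2nc(-c3ccccc3)c(-c3ccccc3)n2C)cc1` differs from compound 2 in one place: 1-methyl-1H-tetrazol-5-yl in place of 1,3-benzothiazol-2-yl on a sulfur. Among the compounds with values here, the only step on record, from compound 1 to compound 2, also changed the group on that sulfur and produced no shift beyond the scatter, but it swapped one bicyclic group for another, whereas here a single small ring enters. Without a closer precedent, compound 3 is expected to show a number 9.8 percentage points lower from compound 2 to compound 3 (within the scatter), with no shift beyond the scatter clearly supported. Compound 3 is estimated at 27% in this assay, in a range from 12% to 42%.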

Compound 3, a percentage reported as activity, at one concentration (the size of the read-out at that concentration, not a potency): 60.6%
Beside the measured number, compound 3's estimate is 33.6 percentage points below it, and the stated range ends below it.
By their numbers in this assay, from the lowest: compounds 1 and 2 (each within the scatter of the next); then compound 3.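

The group on this sulfur clearly matters in this assay: exchanging one two-ring group for another gave no shift beyond the scatter, whereas the single-ring 1-methyl-1H-tetrazol-5-yl gives a number 23.8 percentage points higher from compound 2 to compound 3 (beyond the scatter) and a number 31.2 percentage points higher from compound 1 to compound 3 (beyond the scatter). Compound 3 therefore stands highest of the three, so a two-ring group is not required on this sulfur for this level of effect. Nothing available explains the rise.

This change removes the second ring, adds nitrogen atoms and adds a methyl group all at once, so the compounds shown cannot say which of these matters. A 1-methyl-1H-imidazol-2-yl group or an unsubstituted 1H-tetrazol-5-yl group on the same sulfur would help separate these features.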